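The source may hold more compounds than are shown below. What is called first, only, known or untested is meant among the compounds shown, and "the series" means these compounds.

Measured so far:
compound 1 `CN(C[C@H]1Cc2c(cccc2N2CCN(C3COC3)CC2)CN1)[C@H]1CCCc2cccnc21`: > 30000 nM
compound 2 `Cc1cnc(CN(C)C[C@H]2Cc3c(cccc3N3CCNCC3)CN2)c(C)c1`: > 30000 nM

In a functional assay on CCRF-CEM cells for agonist activity at C-X-C chemokine receptor type 4 (Homo sapiens), read by calcium flux, with a stated time of 25 min (a lower number here means that less compound is needed, a higher number that more compound is needed for the effect), compound 1 gives only a limit, > 30000 nM, not a number. Compound 2 also gives only a limit in this assay, > 30000 nM. Taken together the set shows (the limit of > 30000 nM in this assay, at which 2 of the 2 values shown sit), so no step between measured compounds can be sized here. Compound 3 `CN(C[C@H]1Cc2c(cccc2N2CCN(C3CC3)CC2)CN1)[C@H]1CCCc2cccnc21` differs from compound 1 by cyclopropyl in place of oxetan-3-yl on an amine nitrogen in a ring. With both recorded values sitting at the limit, no direction for this change is indicated. The step of a number no higher from compound 1 to compound 3 (the limit leaves the size open) is expected to be none beyond the scatter. Compound 3 is therefore estimated at 30000 nM, in the range 5000 nM to 100000 nM, most likely again reported only as a limit.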

Compound 3, half-maximal effective concentration: > 30000 nM
Compound 3: a limit, no number; the forecaster's own chance of this, stated with the estimate: 75%; the middle value lies on the limit itself.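

Compound 1 and compound 3 both stand only as limits in this assay, so no step between them can be read: the limit of > 30000 nM in this assay, at which 3 of the 3 values shown sit.

The compounds shown leave open whether cyclopropyl in place of oxetan-3-yl changes anything, and what structure would give a real number in this assay.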